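Two close values, one side-chain swap to test

This account rests on a few compounds, and the source may have more. Where it says the series, first, only, none or still open, it means among the compounds named here.

In a functional assay on MCF7 cells (Homo sapiens) for antiproliferative activity (on this read-out lower numbers stand for stronger inhibition and higher numbers for weaker inhibition), compound 1 `CSCC[C@@H](NC(=O)OC(C)(C)C)C(=O)Nc1ccc(O)c2c(=O)cc(-c3ccccc3Cl)oc12` gives 2800 nM and compound 2 `CC(C)C[C@H](NC(=O)OC(C)(C)C)C(=O)Nc1ccc(O)c2c(=O)cc(-c3ccccc3Cl)oc12` gives 4000 nM. For the measured compounds named here, compound 2 therefore stands within the usual scatter of the only other measured compound, and the two values set no order.

Compound 3 `CSCC[C@H](NC(=O)OC(C)(C)C)C(=O)Nc1ccc(O)c2c(=O)cc(-c3ccccc3Cl)oc12` is reached from compound 2 by (methylsulfanyl)methyl in place of isopropyl on a saturated chain carbon, two bonds along the chain from an amide-type nitrogen and a carbonyl carbon. Cut one bond further out, the same difference reads isobutyl to 2-(methylsulfanyl)ethyl.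

Going by the values given here, no measured step isolates this change, so the only guide is how close compound 1 at 2800 nM and compound 2 at 4000 nM lie. No step beyond the scatter is expected in this assay, in either direction. The expected size is a 1.3-fold lower number from compound 2 to compound 3 (0.10 log units; within the scatter). The estimate for compound 3 is 3200 nM, with an expected range of 1400 nM to 7000 nM.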

Compound 3, half-maximal inhibitory concentration: 20000 nM
Estimate against measurement, compound 3: 6.3-fold (0.80 log units) below, and the stated range ends below it.
By their numbers in this assay, from the lowest: compounds 1 and 2 (each within the scatter of the next); then compound 3.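

In this assay this position is not indifferent to what it carries, which the two earlier values, lying within the scatter of each other, could not show. With (methylsulfanyl)methyl in place of isopropyl, the series moves by a 5.0-fold higher number from compound 2 to compound 3 (0.70 log units; beyond the scatter), so a swap between two side chains of equal heavy-atom count can still give a step beyond the scatter. Configuration at the same saturated chain carbon also counts, as the inversion gives a 7.1-fold higher number from compound 1 to compound 3 (0.85 log units; beyond the scatter), with the R form holding the lower number, and this step can be assigned to configuration alone because of one plain fact: the fact that compounds 1 and 3 differ only in the configuration as drawn

Going by these compounds, whether the isobutyl chain depends on configuration in the same way stays open. So does the standing of a longer chain, an amine or a carboxylic acid at this place, in either configuration.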